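The source may report more compounds than this note shows. Statements on the series, on what has been measured and on what is new or still open speak of the compounds shown alone.

Going by the values given here, compound 3 `NS(=O)(=O)c1ccc(N2N=C(c3cccc(O)c3)C[C@H]2c2ccccc2Cl)cc1` gives 70.3% in a functional assay on the whole organism (strain Wistar albino) for inhibition, with Rattus norvegicus as the target, read by paw edema, with stated times of 30 min and 5 h, at a dose of 0.05 mmol/kg (on this read-out lower numbers stand for less inhibition and higher numbers for more inhibition at the one dose given (going by the name of the read-out)), the highest of the three numbers measured so far. Compound 2 `Cc1ccc([C@@H]2CC(c3cccc(O)c3)=NN2c2ccc(S(N)(=O)=O)cc2)cc1` gives 66% in this assay, and the step of a number 4.3 percentage points higher from compound 2 to compound 3 (within the scatter) stays within the scatter, so the two cannot be ordered. Compound 1 `NS(=O)(=O)c1ccc(N2N=C(c3cccc(O)c3)C[C@H]2c2ccc(Cl)cc2)cc1` gives 51.8% in this assay, and the step of a number 18.5 percentage points higher from compound 1 to compound 3 (beyond the scatter) is beyond the scatter, as is a number 14.2 percentage points higher from compound 1 to compound 2 (beyond the scatter).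

Compound 4 `NS(=O)(=O)c1ccc(N2N=C(c3cccc(O)c3)C[C@H]2c2ccccc2O)cc1` differs from compound 3 by hydroxy in place of chloro on an aromatic carbon. Among the compounds with values here, only one measured step exchanges a substituent on an aromatic carbon, a number 14.2 percentage points higher from compound 1 to compound 2 (beyond the scatter), and that exchange involves methyl, not hydroxy; no measured step introduces a hydroxy group anywhere. The other step, a number 18.5 percentage points higher from compound 1 to compound 3 (beyond the scatter), moves the chloro rather than replacing it. The evidence therefore bears only loosely on this change, and a step of modest size in either direction, or none beyond the scatter, is expected: a number 6.3 percentage points lower from compound 3 to compound 4 (within the scatter). Compound 4 is estimated to give 64% in this assay, somewhere between 48% and 80%.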

Compound 4, a percentage reported as inhibition, in the whole organism at one dose (the size of the read-out at that dose, not a potency): 55.5%
Beside the measured number, compound 4's estimate is 8.5 percentage points above it, and the stated range covers the measured number.
By their numbers in this assay, from the lowest: compounds 1 and 4 (each within the scatter of the next); then compounds 2 and 3 (each within the scatter of the next).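

In this assay, hydroxy in place of chloro on this aromatic carbon gives a number 14.8 percentage points lower from compound 3 to compound 4 (beyond the scatter) and so shows that the identity of the group here matters, whereas the earlier compounds had only shown the chloro moved or exchanged elsewhere. The 2-hydroxyphenyl group in place of 4-methylphenyl gives a number 10.5 percentage points lower from compound 2 to compound 4 (beyond the scatter) as well, while a number 3.7 percentage points higher from compound 1 to compound 4 (within the scatter) leaves those two compounds unordered. Nothing available here accounts for the drop that hydroxy brings.

The compounds shown leave open whether another group on this aromatic carbon, such as an amine or a methoxy group, would stay near compound 3 or near compound 4. Nor do they tell whether hydroxy in place of chloro would do the same on the 4-chlorophenyl group of compound 1.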